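Two aryl ether sugar derivatives and a ring-to-isopropyl swap

The compounds below may be only part of what the source reports. "The series", "measured", "known", "first", "only" and "open" are said of these compounds alone.

The series is built on a shared sugar core carrying two aryl ethers. Compound 1 `CO[C@H]1O[C@H](COc2cccc3c2CCCC3)[C@@H](O)[C@H](O)[C@H]1Oc1ccc(OC2CCCCC2)cc1` has no result in a functional assay on MDA-MB-231 cells (Homo sapiens) for cytotoxicity, read by MTT assay, with a stated time of 48 h; on this read-out lower numbers stand for an effect already at smaller amounts and higher numbers for an effect only at larger amounts of compound: for compound 1 the entry reads "not determined" (no result reported), so it cannot be placed on the scale. Two relatives do have numbers. Compound 2 `CO[C@H]1O[C@H](COc2ccc(C3CCCCC3)cc2)[C@@H](O)[C@H](O)[C@H]1Oc1cccc2c1CCCC2` gives 37000 nM in this assay, and compound 3 `CO[C@H]1O[C@H](COc2ccc(OC3CCCCC3)cc2)[C@@H](O)[C@H](O)[C@H]1Oc1ccc(C(C)C)cc1` gives 25000 nM; the two values sit within the usual scatter of one another.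

Compound 4 `CO[C@H]1O[C@H](COc2cccc(C(C)C)c2)[C@@H](O)[C@H](O)[C@H]1Oc1ccc(OC2CCCCC2)cc1` differs from compound 1 by one change: 3-isopropylphenyl in place of 1,2,3,4-tetrahydronaphthalen-5-yl on an oxygen on a saturated carbon. Among the measured compounds shown here, with no measured step of this kind available, no direction can be drawn from it, and a shift no larger than the scatter is expected in this assay. Resting on the two measured relatives, compound 4 is expected to give about 30000 nM in this assay, with a plausible range from 12000 nM to 75000 nM.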

Compound 4, half-maximal effective concentration: 38000 nM
For compound 4 the middle estimate is 1.3-fold (0.10 log units) below the measured one, and the stated range covers the measured number.
By their numbers in this assay, from the lowest: compounds 3, 2 and 4 (each within the scatter of the next).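

The value of compound 4, 38000 nM in this assay, yields no readable step from compound 1, which holds no number on this scale. From the compounds shown here alone, whether 3-isopropylphenyl in place of 1,2,3,4-tetrahydronaphthalen-5-yl shifts the read-out at all remains open. Nothing at hand bears on this result.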